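This account rests on a few compounds, and the source may have more. Where it says the series, first, only, none or still open, it means among the compounds named here.

In an ADME assay on MT4 cells (Homo sapiens) for cytotoxicity, read by spectrophotometry, with a stated time of 5 days (on this read-out lower numbers stand for higher toxicity in this test and higher numbers for lower toxicity in this test), the three measured compounds give a picture in which the cores differ a great deal but one small substitution does not. Compound 3 `CN(C)CN1C(=O)/C(=N\NC(=S)NO)c2cc(Cl)ccc21` gives 610000 nM in this assay. Compound 1 `Cc1ccc2c(c1)/C(=N/NC(=S)NO)C(=O)N2CN(C)C` carries the same core and differs only by methyl in place of chloro on an aromatic carbon; in this assay compound 1 gives 651000 nM. The step between them, a 1.1-fold higher number from compound 3 to compound 1 (0.03 log units; within the scatter), is within the scatter, so the two values cannot be ordered.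

Compound 2 `CCn1cc(C(=O)O)c(=O)c2cc(F)c(N3CCN(CN4C(=O)/C(=N\NC(=S)NOC)c5cc(Cl)ccc54)CC3)cc21` is built differently: its core is joined to a much larger portion, and the difference between the core of compound 2 and that of compound 3 is not broken down here. In this assay compound 2 gives 193000 nM, the lowest of the three numbers, and its gaps to compound 3 and to compound 1 are both beyond the scatter.

Compound 4 `CCn1cc(C(=O)O)c(=O)c2cc(F)c(N3CCN(CN4C(=O)/C(=N\NC(=S)NOC)c5cc(C)ccc54)CC3)cc21` has not yet been measured in this assay. It differs from compound 2 by methyl in place of chloro on an aromatic carbon, and the place of this change, word for word, is the same as the place of the change from compound 3 to compound 1, so it is the same change. Since that earlier change made the step of a 1.1-fold higher number from compound 3 to compound 1 (0.03 log units; within the scatter), compound 4 is expected to lie close to compound 2, with an expected step of a 1.1-fold higher number from compound 2 to compound 4 (0.04 log units; within the scatter). The estimate for compound 4 in this assay is 210000 nM, expected to fall between 100000 nM and 450000 nM.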

Compound 4, half-maximal cytotoxic concentration: 238000 nM
Beside the measured number, compound 4's estimate is 1.1-fold (0.05 log units) below it; the range from low to high includes it.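

Placing methyl where chloro stood on the core of compound 2 gives, in this assay, a 1.2-fold higher number from compound 2 to compound 4 (0.09 log units; within the scatter), so on this larger core too the change leaves no step that can be told from the scatter. Set beside the earlier case on the smaller core, the two steps agree: the same change on two cores in this assay, a 1.1-fold higher number (0.03 log units; within the scatter) from compound 3 to compound 1 and a 1.2-fold higher number (0.09 log units; within the scatter) from compound 2 to compound 4, 1.2-fold (0.06 log units) apart, within the scatter of two such steps

This shows that, for these two pairs, the exchange of chloro and methyl carried over from one core to the other without a readable effect on the cytotoxicity number, even though the two cores themselves are very different. It does not show that the change would stay this small on a third core, at another place on the ring or in another test, and two pairs, both within the scatter, give no size or direction for the change.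

The compounds shown carry only chloro or methyl at this place, so what fluoro, methoxy or a nitrile on the same aromatic carbon would give remains open. Also open, from the compounds shown here alone, is whether an ethyl ester in place of the carboxylic acid of compound 2, or a longer chain in place of its N-ethyl group, would shift the number in this test.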